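This account rests on a few compounds, and the source may have more. Where it says the series, first, only, none or still open, it means among the compounds named here.

Measured so far in an assay on isolated protein for binding affinity to adenosine receptor A1 (Homo sapiens); a higher number here means a weaker inhibitor, a lower number a stronger inhibitor:

Compound 1 `CCCC1C(=O)c2nc(CN3N=C(Cl)CCC3=O)[nH]c2N(C)C1=O` gives 9200 nM.
Compound 2 `CCCC1C(=O)c2nc(CCCN3N=C(Cl)CCC3=O)[nH]c2N(C)C1=O` gives 1200 nM.
Compound 3 `CCCC1C(=O)c2nc(CN3N=C(c4ccccc4)CCC3=O)[nH]c2N(C)C1=O` gives 2270 nM.

How the cores of compound 1 and compound 2 differ is not broken down here; compound 2 gives the lowest of the three numbers, its gap to compound 1 lies beyond the scatter, its gap to compound 3 within it. One single-point change is measured: phenyl in place of chloro on a carbon with a double bond to nitrogen, and in this assay it gives a 4.1-fold lower number from compound 1 to compound 3 (0.61 log units; beyond the scatter).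

Compound 4 `CCCC1C(=O)c2nc(CCCN3N=C(c4ccccc4)CCC3=O)[nH]c2N(C)C1=O` is not yet measured. It carries the same change on the core of compound 2: phenyl in place of chloro on a carbon with a double bond to nitrogen, at a place described in the same words as before.

For the measured compounds named here, for compound 4 the expected step is a 3.4-fold lower number from compound 2 to compound 4 (0.54 log units; beyond the scatter), which rests on the one measured instance and is given wide room because a 4.1-fold lower number from compound 1 to compound 3 (0.61 log units; beyond the scatter) has been seen only once. Compound 4 is therefore estimated at 350 nM. For compound 4 the expected range runs from 120 nM to 1000 nM.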

Compound 4, inhibition constant: 810 nM
For compound 4 the middle estimate is 2.3-fold (0.36 log units) below the measured one; the range from low to high includes it.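

In this assay phenyl in place of chloro gives a 1.5-fold lower number from compound 2 to compound 4 (0.17 log units; within the scatter) on the core of compound 2, so on this core the change makes no difference beyond the scatter. The size of the step therefore did not carry over unchanged from one core to the other: the same change on two cores in this assay, a 4.1-fold lower number (0.61 log units; beyond the scatter) from compound 1 to compound 3 and a 1.5-fold lower number (0.17 log units; within the scatter) from compound 2 to compound 4, 2.7-fold (0.44 log units) apart, beyond the scatter of two such steps.

For the compounds shown here, with only two cores, this shows that the step depends on the core for this pair, but not what it would be on a further core or which feature of the cores sets it apart.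

Open, going by these compounds, is how an amine or a carboxylic acid in place of chloro on this carbon would read in this assay and how the phenyl for chloro change would read on a core with a longer chain.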